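Methoxy to hydroxyl on the benzyl arm: stability outlook

The source may hold more compounds than are shown below. What is called first, only, known or untested is meant among the compounds shown, and "the series" means these compounds.

Of the compounds shown here, three of one series have been tested in an ADME assay on microsomes from liver (Homo sapiens) for metabolic stability, with a stated time of 10 min; a higher number here means that more of the compound is left, a lower number that less of the compound is left. Compound 1 `COc1cc(OCc2ccccc2OC)c2cc(-c3cn4nc(OC)sc4n3)oc2c1` gives 82%. Compound 2 `COc1cc(OCc2ccccc2OCc2ccccc2)c2cc(-c3cn4nc(OC)sc4n3)oc2c1`, which carries an extra phenyl on the saturated chain carbon bound to an oxygen on the aromatic ring, gives 94%, and the smaller compound 3 `COc1nn2cc(-c3cc4ccccc4o3)nc2s1`, lacking the whole substituted side, gives 80%. Compound 1 thus stands second of the three: its value and that of compound 3 lie within the scatter of each other, while the step of a number 12 percentage points higher from compound 1 to compound 2 (beyond the scatter) is the only one beyond the scatter.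

Compound 4 `COc1cc(OCc2cccc(O)c2)c2cc(-c3cn4nc(OC)sc4n3)oc2c1` differs from compound 1 in one place: 3-hydroxyphenyl in place of 2-methoxyphenyl on a saturated chain carbon bound to an oxygen on an aromatic ring. Within the data shown here, no measured step alters this part of the molecule in the same way; the step from compound 1 to compound 2 adds a phenyl at that carbon rather than exchanging the ring's substituent, so it is only a loose guide. Among the measured compounds shown here, with no direct precedent, a moderate decrease is expected, a number 12 percentage points lower from compound 1 to compound 4 (beyond the scatter), giving an estimated 70% for compound 4, between 50% and 88%.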

Compound 4, percent of the compound remaining: 97%
For compound 4 the middle estimate is 27 percentage points below the measured one, outside the stated range (above it).
By their numbers in this assay, from the lowest: compounds 3 and 1 (each within the scatter of the next); then compounds 2 and 4 (each within the scatter of the next).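

In this assay, among these compounds, the earlier compounds showed a change at this place only through the added phenyl, a number 12 percentage points higher from compound 1 to compound 2 (beyond the scatter). The exchange of 2-methoxyphenyl for 3-hydroxyphenyl gives a number 15 percentage points higher from compound 1 to compound 4 (beyond the scatter), so the substituent on this ring can also be changed, and the number does not fall when a hydroxyl takes the place of the methoxy group on the benzyl arm. Nothing measured here explains why the number rises with this exchange.

This step changes both the group on the ring and where it sits on that ring, and the compounds shown do not tell these two changes apart. From the compounds shown here alone, how an amine or a carboxylic acid on the same ring would fare at this place also stays open.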